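Clearance in rat: from a neopentyl to a phenyl group

The source may report more compounds than this note shows. Statements on the series, on what has been measured and on what is new or still open speak of the compounds shown alone.

Measured compounds:
- Compound 1, `CC(C)(C)[C@H]1C(O)=C(C2=CS(=O)(=O)c3cc(NS(C)(=O)=O)cc(F)c3N2)C(=O)N1Cc1ccc(F)cc1`, 36 mL/min/kg
- Compound 2, `Cc1cc(CN2C(=O)C(C3=CS(=O)(=O)c4cc(NS(C)(=O)=O)ccc4N3)=C(O)[C@@H]2C(C)(C)C)ccc1F`, 101 mL/min/kg
- Compound 3, `CC(C)(C)CCN1C(=O)C(C2=CS(=O)(=O)c3cc(NS(C)(=O)=O)ccc3N2)=C(O)[C@@H]1C(C)(C)C`, > 100 mL/min/kg

In an in vivo ADME assay on the whole organism for pharmacokinetics, with Rattus norvegicus as the target, at a dose of 2 mg/kg by the intravenous route (a lower number here means slower removal, a higher number faster removal of the compound), compound 1 gives 36 mL/min/kg. Compound 3 shares its core with compound 2; in this assay compound 2 gives 101 mL/min/kg. For compound 3 only a limit is known: in this assay it reports > 100 mL/min/kg, which is a limit of the measurement and not a number. For the measured compounds named here, the single one-place step among the measured compounds, a step that the limit leaves unreadable from compound 2 to compound 3, therefore cannot be read, since (the limit of > 100 mL/min/kg in this assay, at which 1 of the 3 values shown sits).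

Compound 4, `CC(C)(C)[C@H]1C(O)=C(C2=CS(=O)(=O)c3cc(NS(C)(=O)=O)ccc3N2)C(=O)N1Cc1ccccc1`, is not yet measured. It differs from compound 3 by phenyl in place of neopentyl on a saturated chain carbon bound to an amide-type nitrogen in a ring. The change thus brings back an aromatic ring at the saturated chain carbon bound to the amide-type nitrogen, as in compound 2, whose value in this assay sits close to the limit reached by compound 3. No readable step bears on this change, so no direction beyond the scatter can be expected; the closest measured neighbour, compound 2, points to fast removal. Compound 4 is therefore expected at 85 mL/min/kg in this assay, within a range of 40 mL/min/kg to 160 mL/min/kg, an estimated step of an at least 1.1-fold lower number from compound 3 to compound 4 (0.07 log units; that floor lies within the scatter) that may again end at the limit.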

Compound 4, clearance: 144 mL/min/kg
Estimate against measurement, compound 4: 1.7-fold (0.23 log units) below, within the range that was stated.
By their numbers in this assay, from the lowest: compound 1; then compounds 2 and 4 (each within the scatter of the next).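

In this assay, phenyl in place of 4-fluoro-3-methylphenyl on the saturated chain carbon bound to the amide-type nitrogen in the ring gives a 1.4-fold higher number from compound 2 to compound 4 (0.15 log units; within the scatter), so the two aromatic groups cannot be told apart at this position and removal stays fast with either. For compound 3 the assay reports > 100 mL/min/kg, which is a limit and not a number. The steps that involve compound 3, including the change from neopentyl to phenyl, therefore cannot be read: the limit of > 100 mL/min/kg in this assay, at which 1 of the 4 values shown sits.

Compound 1 differs from each of the other compounds in more than one place, so nothing shown ties its value of 36 mL/min/kg to a single change. From the compounds shown here alone, it also remains open whether an amine, a carboxylic acid or a longer chain ending in phenyl, placed on this saturated chain carbon, would shift the clearance in this assay beyond the usual scatter.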